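The source may hold more compounds than are shown below. What is called first, only, known or untested is meant among the compounds shown, and "the series" means these compounds.

In an assay on isolated protein for inhibition of ubiquitin carboxyl-terminal hydrolase 7 (Homo sapiens), with stated times of 30 min and 2 h (on this read-out lower numbers stand for stronger inhibition and higher numbers for weaker inhibition), compound 3, `Cn1nc2c(=O)n(CC3(O)CCN(Cc4ccc(-n5cccn5)cc4Cl)CC3)cnc2c1-c1ccc(CN)cc1`, gives 233 nM. Among the three compounds measured so far this is the highest of the numbers, but the others lie close to it: compound 2, `Cn1nc2c(=O)n(CC3(O)CCN(Cc4ccc(-n5ccnc5)cc4Cl)CC3)cnc2c1-c1ccc(CN)cc1`, gives 228 nM, and compound 1, `Cn1nc2c(=O)n(CC3(O)CCN(Cc4ccc(-c5n[nH]c(=O)o5)cc4Cl)CC3)cnc2c1-c1ccc(CN)cc1`, gives 171 nM. The step of a 1.4-fold higher number from compound 1 to compound 3 (0.13 log units; within the scatter) and the step of a 1.0-fold higher number from compound 2 to compound 3 (0.01 log units; within the scatter) both stay within the scatter, as does a 1.3-fold higher number from compound 1 to compound 2 (0.12 log units; within the scatter), so the three five-membered rings tried at this position on the shared core have given numbers that cannot be told apart.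

Compound 4, `Cn1nc2c(=O)n(CC3(O)CCN(Cc4ccc(-c5cncs5)cc4Cl)CC3)cnc2c1-c1ccc(CN)cc1`, carries the change (1,3-thiazol-5-yl in place of 1H-pyrazol-1-yl on an aromatic carbon). The measured steps that bear on this exchange are those from compound 1 to compound 3 and from compound 2 to compound 3, each of which replaced one five-membered aromatic ring with two hetero atoms or three by another, and each of which stayed within the scatter. On that basis the expectation for compound 4 in this assay is no step beyond the scatter in either direction, the step of a 1.0-fold lower number from compound 3 to compound 4 (0.01 log units; within the scatter) being the estimate. Compound 4 is therefore expected to give about 230 nM, with a range from 110 nM to 480 nM.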

Compound 4, half-maximal inhibitory concentration: 117 nM
Estimate against measurement, compound 4: 2.0-fold (0.29 log units) above, within the range that was stated.
By their numbers in this assay, from the lowest: compounds 4, 1, 2 and 3 (each within the scatter of the next).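

In this assay, 1,3-thiazol-5-yl brings a ring holding sulfur to this position, para to a large group and meta to a chloro group, and the comparisons with all three earlier rings stay within the scatter: a 2.0-fold lower number from compound 3 to compound 4 (0.30 log units; within the scatter), a 1.9-fold lower number from compound 2 to compound 4 (0.29 log units; within the scatter) and a 1.5-fold lower number from compound 1 to compound 4 (0.16 log units; within the scatter). The exchange for 1H-pyrazol-1-yl keeps the counts of heavy atoms, hydrogen-bond donors and hydrogen-bond acceptors and swaps one ring nitrogen for sulfur, and the four five-membered aromatic rings now shown at this position still cannot be told apart, even though the step from the pyrazole is the largest of those listed here. Nothing available gives a reason for any of these numbers.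

The compounds shown leave open whether any group at this position would give a number beyond the scatter, since all four carry a five-membered aromatic ring on the same chlorinated benzene ring of the shared core. A six-membered pyridine ring, a carboxylic acid, a primary amine or a plain hydrogen in its place would test how far that holds.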